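The source may hold more compounds than are shown below. What is called first, only, known or untested is meant among the compounds shown, and "the series" means these compounds.

For the measured compounds named here, compound 1 `COc1ccc(Cl)cc1C(=O)Nc1ccc(C2=NN(C)C(c3ccccc3[N+](=O)[O-])C2)cc1` stands highest of the two compounds measured so far: in a functional assay on the whole organism (plasma, strain albino) for inhibition, with Rattus norvegicus as the target, with stated times of 1 h and 4 h, at a dose of 25 mg/kg by the oral route (a lower number here means a weaker effect, a higher number a stronger effect of the compound at the dose given), compound 1 gives 83.8%. Compound 2 `COc1ccc(Cl)cc1C(=O)Nc1ccc(C2=NN(C)C(c3ccc([N+](=O)[O-])cc3)C2)cc1` differs from it only at the saturated ring carbon, where 4-nitrophenyl replaces 2-nitrophenyl, and in this assay compound 2 gives 71.4%, so that a number 12.4 percentage points lower from compound 1 to compound 2 (beyond the scatter). Compound 3 `COc1ccc(Cl)cc1C(=O)Nc1ccc(C2=NN(c3ccccc3)C(c3ccccc3[N+](=O)[O-])C2)cc1` has not been measured. It differs from compound 1 at another place, the amine nitrogen in the ring: phenyl in place of methyl on an amine nitrogen in a ring. Going by the values given here, no measured step touches that nitrogen, so nothing known bears directly on the change; the one known step, a number 12.4 percentage points lower from compound 1 to compound 2 (beyond the scatter), shows only that a single change on the shared core can shift the read-out modestly. Compound 1 already sits high, so a large rise is hard to reach. The expected step is therefore a number 8.8 percentage points lower from compound 1 to compound 3 (within the scatter), within or close to the scatter and downward if anything. Compound 3 is estimated at 75%, with a range from 50% to 92%.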

Compound 3, a percentage reported as inhibition, in the whole organism at one dose (the size of the read-out at that dose, not a potency): 73.3%
Estimate against measurement, compound 3: 1.7 percentage points above; measured number inside the range.
By their numbers in this assay, from the lowest: compounds 2 and 3 (each within the scatter of the next); then compound 1.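

At the amine nitrogen in the ring, which the earlier step did not touch, the read-out proves sensitive: in this assay, phenyl in place of methyl gives a number 10.5 percentage points lower from compound 1 to compound 3 (beyond the scatter) as a modest step. The position next to the ring atom that bears a 2-nitrophenyl group thus accepts a six-membered aromatic ring, with a clear effect remaining at the dose given, as compound 3 gives 73.3% here. Nothing measured on these compounds accounts for the step.

From the compounds shown here alone, whether the same change would give a similar step with 4-nitrophenyl on the saturated ring carbon remains open. Going by these compounds, it is also open how an ethyl or benzyl group on that nitrogen, or a phenyl group carrying an amine or a carboxylic acid, would read in this assay.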